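The source may report more compounds than this note shows. Statements on the series, on what has been measured and on what is new or still open speak of the compounds shown alone.

Measured so far:
compound 1 `Nc1nc(N)c2cc(CSC(=S)N3CCN(c4ccc(Cl)cc4)CC3)ccc2n1`: 5210 nM
compound 2 `Nc1nc(N)c2cc(CSC(=S)N3CCN(c4ccc(Cl)c(Cl)c4)CC3)ccc2n1`: 2940 nM

In a functional assay on A549 cells (Homo sapiens) for antiproliferative activity, read by MTT assay, with a stated time of 72 h (a higher number here means a weaker inhibitor, a lower number a stronger inhibitor), compound 1 gives 5210 nM, the highest of the two numbers shown, although the gap to compound 2 is within the scatter. Compound 2 gives 2940 nM, and the step of a 1.8-fold lower number from compound 1 to compound 2 (0.25 log units; within the scatter). Compound 3 `Nc1nc(N)c2cc(CSC(=S)N3CCN(c4ncccn4)CC3)ccc2n1` differs from compound 1 in one place: pyrimidin-2-yl in place of 4-chlorophenyl on an amine nitrogen in a ring. For the measured compounds named here, the only measured step concerns chloro in place of hydrogen on an aromatic carbon and says nothing about exchanging the whole group on the amine nitrogen, so no shift beyond the scatter is expected in either direction. For compound 3 the estimated value is 6500 nM, within a range from 2500 nM to 20000 nM. The expected step is a 1.2-fold higher number from compound 1 to compound 3 (0.10 log units; within the scatter).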

Compound 3, half-maximal inhibitory concentration: 4010 nM
Beside the measured number, compound 3's estimate is 1.6-fold (0.21 log units) above it, and the stated range covers the measured number.
By their numbers in this assay, from the lowest: compounds 2, 3 and 1 (each within the scatter of the next).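

In this assay, replacing 4-chlorophenyl with pyrimidin-2-yl on the amine nitrogen in a ring gives a 1.3-fold lower number from compound 1 to compound 3 (0.11 log units; within the scatter), and replacing 3,4-dichlorophenyl with it gives a 1.4-fold higher number from compound 2 to compound 3 (0.13 log units; within the scatter). This position therefore accepts a six-membered aromatic ring with 2 hetero atoms and no chlorine in place of a carbon-only aromatic ring, with no shift beyond the scatter. No supporting measurement offers an explanation for this result. Still open, from the compounds shown here alone, is whether a simple alkyl chain, a benzyl group or an acyl group on this nitrogen would move the number beyond the scatter.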